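Pyrrolyl cyanopyridines: phenyl for thienyl in a flat series

The compounds below may be only part of what the source reports. "The series", "measured", "known", "first", "only" and "open" are said of these compounds alone.

Working notes on a small set of 1-methyl-1H-pyrrol-2-yl-bearing nitrile compounds read in a functional assay on UO-31 cells (Homo sapiens) for inhibition, read by sulforhodamine B assay, with a stated time of 48 h; on this read-out lower numbers stand for stronger inhibition of growth and higher numbers for weaker inhibition of growth. Compound 1 `COc1ccc(-c2cc(-c3cccn3C)c(C#N)c(=O)[nH]2)cc1OC` gives 85100 nM in this assay. Compound 2 `Cn1cccc1-c1cc(-c2cccs2)nc(N)c1C#N` returns only the limit of the assay, > 100000 nM, and no number. Compound 3 `Cn1cccc1-c1cc(-c2ccccc2)[nH]c(=O)c1C#N` likewise sits at the limit, > 100000 nM. Among the compounds with values here, compound 2 therefore cannot be placed against the others beyond the fact that it shares (the limit of > 100000 nM in this assay, at which 2 of the 3 values shown sit); the one numbered value, from compound 1, is itself weak, and the set as a whole shows essentially no growth inhibition in this assay.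

The next member, compound 4 `Cn1cccc1-c1cc(-c2ccccc2)nc(N)c1C#N`, differs from compound 2 in one place: phenyl in place of thiophen-2-yl on an aromatic carbon. Within the data shown here, no pair of measured compounds reproduces this change, so nothing in the present numbers sets a direction for it. Given that compound 2 stands at > 100000 nM, the expectation is no step beyond the scatter, and compound 4 is most likely to return the limit again.

Compound 4 is estimated at 120000 nM in this assay, within 50000 nM to 400000 nM. That estimate corresponds to an expected step that the limit leaves unreadable from compound 2 to compound 4.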

Compound 4, concentration for 50% growth inhibition: > 100000 nM
Compound 4 ended at the assay's limit; the forecaster's own chance of this, stated with the estimate: 75%; the middle value does not contradict the limit.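

Compound 2 and compound 4 both stand at a limit and not at a number, so no step can be read for phenyl in place of thiophen-2-yl: the limit of > 100000 nM in this assay, at which 3 of the 4 values shown sit. The compounds shown leave open whether this change has any effect on growth inhibition in this assay in a compound that gives a numbered value.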